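This account rests on a few compounds, and the source may have more. Where it says the series, first, only, none or still open, it means among the compounds named here.

For the measured compounds named here, compound 2, with the structure `C=C(Br)C(=O)Nc1cccc(-c2cn3c(-c4ccc(OC)cc4)csc3n2)c1`, gives 620 nM in a functional assay on FM3A cells (Mus musculus) for inhibition, read by cell counting, with a stated time of 2 days (a lower number here means a stronger inhibitor, a higher number a weaker inhibitor), the lower of the two numbers measured so far. Compound 1, with the structure `COc1ccc(-c2nn3cc(-c4cccc(N)c4)nc3s2)cc1OC`, gives 13000 nM in this assay, a higher number that lies beyond the usual scatter of such measurements. The two compounds differ in more than one place, so their gap cannot be traced to a single change.

Compound 3, with the structure `C=C(Br)C(=O)Nc1cccc(-c2cn3c(-c4ccccc4)csc3n2)c1`, is built from compound 2 by one change: hydrogen in place of methoxy on an aromatic carbon. Going by the values given here, no measured pair in this set shows the same change, so nothing here sets its size. A modest step from compound 2 to compound 3 is expected, most likely toward a somewhat higher number, a 1.6-fold higher number from compound 2 to compound 3 (0.21 log units; within the scatter). Compound 3 is therefore estimated at 1000 nM in this assay, with a range from 300 nM to 3500 nM.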

Compound 3, half-maximal inhibitory concentration: 1300 nM
Compound 3: the middle estimate sits 1.3-fold (0.11 log units) below what was measured, and the stated range covers the measured number.
By their numbers in this assay, from the lowest: compound 2; then compound 3; then compound 1.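

For the compounds shown here, replacing 4-methoxyphenyl with phenyl gives a 2.1-fold higher number from compound 2 to compound 3 (0.32 log units; beyond the scatter) in this assay, the first comparison in this set where only one place differs. The step is modest but beyond the scatter, so the methoxy at this place goes with the lower number, while compound 3 still gives a measurable value without it, showing that this group is not required for inhibition here. Nothing available explains why the number rises when the methoxy leaves.

This single pair cannot show whether the trend extends to other groups at this place, such as a hydroxyl, an amine, a fluorine or a longer ether like ethoxy. It also leaves open whether the same change would have a similar effect on the core of compound 1.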